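Methoxy to ethoxy on compound 3

The source may hold more compounds than are shown below. What is called first, only, known or untested is meant among the compounds shown, and "the series" means these compounds.

In a functional assay on MDA-MB-468 cells (Homo sapiens) for antiproliferative activity (a higher number here means a weaker inhibitor of growth, a lower number a stronger inhibitor of growth), compound 1 (`COc1ccc(-c2nc3cc(F)ccc3s2)cc1F`) gives 640 nM and compound 2 (`COc1ccc(-c2nc3cc(F)ccc3s2)cc1Br`) gives 420 nM as its value, a pair separated by a step within the scatter (a 1.5-fold lower number from compound 1 to compound 2 (0.18 log units; within the scatter)). Compound 3 (`COc1ccc(-c2nc3cc(F)ccc3s2)cc1OC`) gives < 0.1 nM as a limit of this assay and not a number. Methoxy in place of fluoro or bromo is a large step (an at least 6400-fold lower number from compound 1 to compound 3 (3.80 log units; beyond the scatter)) and (an at least 4200-fold lower number from compound 2 to compound 3 (3.62 log units; beyond the scatter)). Compound 4 (`CCOc1cc(-c2nc3cc(F)ccc3s2)ccc1OC`) turns methoxy into ethoxy (methyl in place of hydrogen on a saturated chain carbon bound to an oxygen on an aromatic ring) on the group that entered in those large steps. For the measured compounds named here, no measured step alters that group itself, so those steps bear on it only loosely, and a much smaller rise in the number of this assay is expected (an at least 5.0-fold higher number from compound 3 to compound 4 (0.69 log units; beyond the scatter)). For compound 4 the estimate is 0.5 nM with an expected range from 0.05 nM to 50 nM in this series.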

Compound 4, concentration for 50% growth inhibition: 92 nM
For compound 4 the middle estimate is 180-fold (2.26 log units) below the measured one, and the stated range ends below it.
By their numbers in this assay, from the lowest: compound 4; then compounds 2 and 1 (each within the scatter of the next). At a limit, below all of these: compound 3.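

In this assay, one added methyl on the methoxy group of compound 3 is a large loss (an at least 920-fold higher number from compound 3 to compound 4 (2.96 log units; beyond the scatter)), so this place responds sharply to a change within the group itself and not only to replacing it. Ethoxy keeps only a modest edge over the halogens (a 4.6-fold lower number from compound 2 to compound 4 (0.66 log units; beyond the scatter); a 7.0-fold lower number from compound 1 to compound 4 (0.84 log units; beyond the scatter)). The large step is a bound and not a measured size, as compound 3 stands at a limit of the assay: the limit of < 0.1 nM in this assay, at which 1 of the 4 values shown sits.

Open, going by these compounds, is what a hydroxy group, an amine or a propoxy chain would give here, and how far the number rises along a longer chain.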